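Removing the ring nitrogen aryl group: what to expect

The compounds below may be only part of what the source reports. "The series", "measured", "known", "first", "only" and "open" are said of these compounds alone.

Measured so far:
- compound 1 `COc1ncc(-c2ccc3c(c2)N(c2ccc(C)cc2)C(=O)CO3)cc1NS(=O)(=O)c1ccc(F)cc1`: 15400 nM
- compound 3 `CC(C)N1C(=O)COc2ccc(-c3cnc(Cl)c(NS(=O)(=O)c4ccc(F)cc4)c3)cc21`: 26600 nM
- compound 2 `O=C1COc2ccc(-c3cnc4ccccc4c3)cc2N1C1CCCCC1`: a limit, > 40000 nM

In a functional assay on MCF7 cells (Homo sapiens) for antiproliferative activity, read by MTT assay, with a stated time of 72 h (a lower number here means a stronger inhibitor, a higher number a weaker inhibitor), compound 1 gives 15400 nM. Compound 3 gives 26600 nM in this assay, and the gap between compound 1 and compound 3 lies within the usual scatter, so the two cannot be told apart. Compound 2 reaches only a limit of this assay, > 40000 nM; one of the three values shown is such a limit (the limit of > 40000 nM in this assay, at which 1 of the 3 values shown sits). Compound 1 therefore has the lowest actual number shown, but only by a margin that means little.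

The unmeasured compound 4 `COc1ncc(-c2ccc3c(c2)NC(=O)CO3)cc1NS(=O)(=O)c1ccc(F)cc1` differs from compound 1 in one place: hydrogen in place of 4-methylphenyl on an amide-type nitrogen in a ring. Among the compounds with values here, no pair of measured compounds shows this exact change, so the size of its effect is unknown. The weak numbers across all three measured compounds suggest that compound 4 is expected to stay in the same weak region, and the expected step of a 1.6-fold higher number from compound 1 to compound 4 (0.21 log units; within the scatter) is likely small, if any, with a fair chance of reaching the limit. Compound 4 is estimated at 25000 nM, in the range 8000 nM to 60000 nM.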

Compound 4, half-maximal inhibitory concentration: 32300 nM
Beside the measured number, compound 4's estimate is 1.3-fold (0.11 log units) below it, within the range that was stated.
By their numbers in this assay, from the lowest: compounds 1, 3 and 4 (each within the scatter of the next, the first and the last beyond it). At a limit, above all of these: compound 2.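

In this assay, within the data shown here, hydrogen in place of 4-methylphenyl on the amide-type nitrogen in a ring gives a 2.1-fold higher number from compound 1 to compound 4 (0.32 log units; beyond the scatter) and this is the first reading of that position with the rest of the molecule held fixed. The step is modest, so the 4-methylphenyl group is worth only a little here, and compound 4 still gives a real number and not a limit without any group on that nitrogen. Nothing shown here gives a reason for this step.

As far as these compounds go, whether an ethyl group, a benzyl group or a chain ending in an amine on this nitrogen would give a lower number than hydrogen or 4-methylphenyl remains open. Also open, from the compounds shown here alone, is whether the same step would appear with other groups elsewhere on the shared core, since compound 2 and compound 3 each differ from compound 1 in more than one place.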